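Swapping Hydrogen for Chloro on the Shared Core

The compounds below may be only part of what the source reports. "The series", "measured", "known", "first", "only" and "open" are said of these compounds alone.

For the measured compounds named here, compound 2 `O=C(O)c1ccc2sc(Cn3ccnc3)cc2c1` gives 15 nM in an assay for inhibition of Thromboxane-A synthase (Homo sapiens) (a lower number here means a stronger inhibitor, a higher number a weaker inhibitor), the lowest of the two numbers measured so far, though it sits within the scatter of compound 1 `Cc1c(Cn2ccnc2)sc2ccc(C(=O)O)cc12`, which gives 17 nM. Going by the values given here, the only measured step, a 1.1-fold lower number from compound 1 to compound 2 (0.05 log units; within the scatter), replaced methyl by hydrogen at the same place where compound 3 `O=C(O)c1ccc2sc(Cn3ccnc3)c(Cl)c2c1` now carries chloro in place of hydrogen on an aromatic carbon. That exchange was flat, and the new step of no change at the digits printed from compound 2 to compound 3 (within the scatter) is accordingly expected to stay within the scatter. Compound 3 is therefore estimated at about 15 nM, with a range from 6 nM to 40 nM.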

Compound 3, half-maximal inhibitory concentration: 22 nM
The estimate for compound 3 lay 1.5-fold (0.17 log units) below the measured number; measured number inside the range.
By their numbers in this assay, from the lowest: compounds 2, 1 and 3 (each within the scatter of the next).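

In this assay, the position next to the ring atom that bears the (1H-imidazol-1-yl)methyl group now also accepts chloro: a 1.5-fold higher number from compound 2 to compound 3 (0.17 log units; within the scatter) and a 1.3-fold higher number from compound 1 to compound 3 (0.11 log units; within the scatter) both stay within the scatter. Hydrogen, methyl and chloro at this place therefore cannot be told apart by this read-out. Nothing available explains this tolerance.

As far as these compounds go, whether an amine, a methoxy group or a longer chain at this place would also leave the number unchanged remains open. So does whether chloro would behave alike elsewhere on the shared core.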